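The source may hold more compounds than are shown below. What is called first, only, known or untested is meant among the compounds shown, and "the series" means these compounds.

Compound 2 `CCCn1c(=O)[nH]c2nc(-c3ccc(S(=O)(=O)N4CCN(c5ccc(Br)cc5)CC4)cc3)[nH]c2c1=O` gives, in an assay on CHO cells for displacement of a labelled ligand from adenosine receptor A2b (Homo sapiens), read by scintillation counting, with a stated time of 75 min, in the presence of a further agent that is not named here (a lower number here means a stronger inhibitor, a higher number a weaker inhibitor), a value of 0.0835 nM. Among the three measured compounds this is the lowest number: compound 3 `CCCn1c(=O)[nH]c2nc(-c3ccc(S(=O)(=O)N4CCN(c5cccc(Cl)c5)CC4)cc3)[nH]c2c1=O` gives 0.342 nM, and compound 1 `CCCn1c(=O)c2[nH]c(-c3ccc(S(=O)(=O)N4CCN(c5ccc(Cl)cc5)CC4)cc3)nc2n(C)c1=O` gives 1.91 nM. Compound 4 `CCCn1c(=O)[nH]c2nc(-c3ccc(S(=O)(=O)N4CCN(Cc5cccc(Br)c5)CC4)cc3)[nH]c2c1=O` differs from compound 2 in one place: 3-bromobenzyl in place of 4-bromophenyl on an amine nitrogen in a ring. Going by the values given here, only one measured step bears on this change, and only partly, since it swaps one halophenyl group for another rather than adding a benzyl link: a 4.1-fold higher number from compound 2 to compound 3 (0.61 log units; beyond the scatter). The benzyl link itself has no precedent among these compounds, so a modest weakening is expected rather than a large one. For compound 4 the estimate is 0.4 nM, within a range from 0.12 nM to 1.3 nM. This estimate means a 4.8-fold higher number from compound 2 to compound 4 (0.68 log units; beyond the scatter), expected to lie beyond the scatter.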

Compound 4, inhibition constant: 0.148 nM
Compound 4: the middle estimate sits 2.7-fold (0.43 log units) above what was measured; measured number inside the range.
By their numbers in this assay, from the lowest: compounds 2 and 4 (each within the scatter of the next); then compound 3; then compound 1.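

Putting 3-bromobenzyl in place of 4-bromophenyl on the amine nitrogen in the ring gives a 1.8-fold higher number from compound 2 to compound 4 (0.25 log units; within the scatter) and thus no readable loss, so this position accepts the group with its extra carbon. Set against the 3-chlorophenyl group, the same 3-bromobenzyl group gives a 2.3-fold lower number from compound 3 to compound 4 (0.36 log units; beyond the scatter) while the halogen changes as well, so that step cannot be credited to the added carbon alone. Nothing measured here explains these numbers. Still open, from the compounds shown here alone, is how plain benzyl without bromine, 4-bromobenzyl or a longer chain such as phenethyl would fare here.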